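The compounds below may be only part of what the source reports. "The series", "measured", "known", "first", "only" and "open" are said of these compounds alone.

Of the compounds shown here, two have been measured in a functional assay on A375P cells (Homo sapiens) for cytotoxicity, read by MTT assay; a lower number here means a stronger inhibitor, a higher number a weaker inhibitor. Compound 1 `NC(=O)c1ccc2c(ccn2-c2ccc(NC(=O)Nc3ccc(Cl)c(Cl)c3)cc2)n1` gives 3200 nM. Compound 2 `NC(=O)c1ccc2c(ccn2-c2ccc(NC(=O)Nc3cccc(Cl)c3Cl)cc2)n1` gives 4600 nM, the highest of the two numbers, with compound 1 nearest; the step of a 1.4-fold higher number from compound 1 to compound 2 (0.16 log units; within the scatter) does not stand out from the scatter. Compound 3 `NC(=O)c1ccc2c(ccn2-c2ccc(NC(=O)Nc3ccc(Cl)c(C(F)(F)F)c3)cc2)n1` differs from compound 2 by 4-chloro-3-(trifluoromethyl)phenyl in place of 2,3-dichlorophenyl on an amide-type nitrogen. For the measured compounds named here, the only measured step bearing on this exchange of the aryl group on the urea-type nitrogen is a 1.4-fold higher number from compound 1 to compound 2 (0.16 log units; within the scatter), which lay within the scatter, so no step beyond the scatter is expected in this assay, in either direction. For compound 3 the estimate is 3200 nM, within 1200 nM to 8500 nM. This estimate implies the step of a 1.4-fold lower number from compound 2 to compound 3 (0.16 log units; within the scatter).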

Compound 3, half-maximal inhibitory concentration: 9900 nM
The estimate for compound 3 lay 3.1-fold (0.49 log units) below the measured number, and the stated range ends below it.
By their numbers in this assay, from the lowest: compounds 1 and 2 (each within the scatter of the next); then compound 3.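

In this assay, the aryl group on the amide-type nitrogen now gives a change beyond the scatter: a 2.2-fold higher number from compound 2 to compound 3 (0.33 log units; beyond the scatter). The closest comparison is a 3.1-fold higher number from compound 1 to compound 3 (0.49 log units; beyond the scatter), where trifluoromethyl in place of chloro on an aromatic carbon is the only difference, so this single exchange is enough to raise the number. Nothing measured here points to a cause for this rise.

Open, going by these compounds, is whether methyl, methoxy or nitrile in place of that trifluoromethyl would stay with compound 1 or move with compound 3. Also open, on these data alone, is how an amine or carboxylic acid on this aryl ring would read.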